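A few compounds are considered here, and "the series" means these few. Any claim that something is new, unique, unknown or untested is made for them only; others in the source may bear on it.

Of the compounds shown here, three have been tested so far in a functional assay on PC-3 cells (Homo sapiens) for cytotoxicity, read by MTT assay, with a stated time of 72 h (a lower number here means a stronger inhibitor, a higher number a weaker inhibitor), on this series. Compound 1 (`O=C(N/N=C/c1cccc(Br)c1)Nc1cc2c(Nc3ccc(F)c(Cl)c3)ncnc2cc1O[C@H]1CCOC1`) gives 15500 nM as its reading, and compound 2 (`CCN(CC)c1ccc(/C=N/NC(=O)Nc2cc3c(Nc4ccc(F)c(Cl)c4)ncnc3cc2O[C@H]2CCOC2)c(O)c1`) gives 4590 nM as its reading. Compound 3 (`COc1cc2ncnc(Nc3ccc(F)c(Cl)c3)c2cc1NC(=O)N/N=C/c1cccc(Br)c1`) stands apart with the result "not active" (no number reported), so it has no exact place beside the other two.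

Compound 4 (`COc1cc2ncnc(Nc3ccc(F)c(Cl)c3)c2cc1NC(=O)N/N=C/c1cc(OC)c(OC)c(OC)c1`) alters compound 3 at one place, with 3,4,5-trimethoxyphenyl in place of 3-bromophenyl on a carbon with a double bond to nitrogen. For the measured compounds named here, only one measured step replaces the same group at that place: a 3.4-fold lower number from compound 1 to compound 2 (0.53 log units; beyond the scatter) with 4-(diethylamino)-2-hydroxyphenyl entering, a modest change beyond the scatter. That step has a different entering group and does not start from compound 3, so it is only a rough guide. A similarly modest move toward a lower number is therefore expected in this assay from an unknown starting point, and compound 4 may also go without a number. Compound 4 is estimated at 30000 nM (expected range 10000 nM to 80000 nM).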

Compound 4, half-maximal inhibitory concentration: 36500 nM
Compound 4: the middle estimate sits 1.2-fold (0.09 log units) below what was measured, within the range that was stated.
By their numbers in this assay, from the lowest: compound 2; then compound 1; then compound 4.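

Compound 3 carries no number in this assay, so the change from compound 3 to compound 4 cannot be read as a step. The compounds shown leave open how 3,4,5-trimethoxyphenyl compares with 3-bromophenyl at this place. No evidence here bears on the reading of compound 4.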